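Removing the methoxy from the cyclobutyl amide of compound 1

The compounds below may be only part of what the source reports. "The series", "measured", "known", "first", "only" and "open" are said of these compounds alone.

Measured compounds:
- compound 1 `CCn1c(-c2cnc(C)nc2)nc2c(N[C@H]3CCN(C(=O)[C@H]4C[C@@H](OC)C4)C3)ncnc21`: 10 10^-6 cm/s
- compound 2 `CCn1c(-c2cnc(C)nc2)nc2c(O[C@H]3CCN(C(=O)C4CC4)C3)ncnc21`: 28 10^-6 cm/s
- compound 3 `CCC(=O)N1CC[C@H](Oc2ncnc3c2nc(-c2cnc(C)nc2)n3CC)C1`: 21 10^-6 cm/s

In an ADME assay on LLC-PK1 cells (Sus scrofa) for permeability (on this read-out higher numbers stand for higher permeability and lower numbers for lower permeability), compound 1 gives the lowest number of the three; compound 3 and compound 2 stand above it beyond the scatter. Compound 4 `CCn1c(-c2cnc(C)nc2)nc2c(N[C@H]3CCN(C(=O)C4CCC4)C3)ncnc21` differs from compound 1 only at the amide: hydrogen in place of methoxy on a saturated ring carbon. Going by the values given here, the one measured step that touches the acyl group, a 1.3-fold lower number from compound 2 to compound 3 (0.12 log units; within the scatter), was within the scatter, although it runs between compounds that carry an ether rather than the amine link of compound 1. On that basis only a modest change is expected, so the estimate for compound 4 in this assay is 16 10^-6 cm/s (range 8 10^-6 cm/s to 32 10^-6 cm/s), a step of a 1.6-fold higher number from compound 1 to compound 4 (0.20 log units; within the scatter) that is expected to stay near the scatter.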

Compound 4, apparent permeability: 32 10^-6 cm/s
For compound 4 the middle estimate is 2.0-fold (0.30 log units) below the measured one; the measured number falls inside the stated range.
By their numbers in this assay, from the lowest: compound 1; then compounds 3, 2 and 4 (each within the scatter of the next).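

Putting hydrogen in place of methoxy on a saturated ring carbon gives a 3.2-fold higher number from compound 1 to compound 4 (0.51 log units; beyond the scatter) in this assay. Going by these compounds alone, this is the first single change in the set that lies beyond the scatter, so the substituent on the cyclobutyl ring counts for this read-out in a way the earlier acyl step, a 1.3-fold lower number from compound 2 to compound 3 (0.12 log units; within the scatter), did not show. Nothing measured here explains the step.

Going by these compounds, whether a hydroxyl or an amine on that ring carbon would stay near compound 1 or near compound 4 remains open. So does whether a methoxy on the cyclopropyl amide of compound 2 would give a step of similar size.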